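The compounds below may be only part of what the source reports. "The series", "measured", "known", "first", "only" and "open" are said of these compounds alone.

Series values in a functional assay on PC-3 cells (Homo sapiens) for cytotoxicity, read by WST assay, with a stated time of 24 h; a lower number here means a stronger inhibitor, a higher number a weaker inhibitor:

- compound 1 `COc1ccc2[nH]cc(/C=C(\C#N)C(=O)c3c[nH]c4ccccc34)c2c1`: 33200 nM
- compound 2 `N#C/C(=C\c1cn(Cc2ccc(Cl)cc2)c2ccc(Br)cc12)C(=O)c1c[nH]c2ccccc12`: 47100 nM
- compound 3 `COc1ccc2[nH]cc(/C=C(\C#N)C(=O)c3c[nH]c4cc(F)ccc34)c2c1`: > 50000 nM (a limit, not a number)

Compound 3 has no number to start from. In this assay compound 3 gives > 50000 nM, and this is a limit of the assay. The series record shows (the limit of > 50000 nM in this assay, at which 1 of the 3 values shown sits).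

The next compound is compound 4 `COc1ccc2c(C(=O)/C(C#N)=C/c3c[nH]c4ccc(OC)cc34)c[nH]c2c1`, still to be measured. It carries methoxy in place of fluoro on an aromatic carbon.

Within the data shown here, the one measured step at this carbon has fluoro in place of hydrogen. Its size is an at least 1.5-fold higher number from compound 1 to compound 3 (0.17 log units; that floor lies within the scatter). Among the measured compounds shown here, that step is small and rests on a limit, and no measured step covers methoxy at this carbon. For the measured compounds named here, compound 2 differs from the others in more than one place and gives no step for this change.

On that thin basis, no step beyond the scatter is expected in this assay, and neither direction is favoured. The expected shift is an at least 1.2-fold lower number from compound 3 to compound 4 (0.09 log units; that floor lies within the scatter). A result reported only as a limit would be no surprise. For compound 4 the estimated value is 40000 nM, with an expected range of 15000 nM to 50000 nM.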

Compound 4, half-maximal inhibitory concentration: 31100 nM
For compound 4 the middle estimate is 1.3-fold (0.11 log units) above the measured one, within the range that was stated.
By their numbers in this assay, from the lowest: compounds 4, 1 and 2 (each within the scatter of the next). At a limit, above all of these: compound 3.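

In this assay, among these compounds, methoxy in place of hydrogen on this aromatic carbon gives a 1.1-fold lower number from compound 1 to compound 4 (0.03 log units; within the scatter), the first comparison at this carbon with a measured number at both ends, and it shows no change beyond the scatter. Methoxy in place of fluoro gives an at least 1.6-fold lower number from compound 3 to compound 4 (0.20 log units; that floor lies within the scatter), which is only a floor on the size of the step and not a full measure of it. Compound 3 remains a limit and not a number, so fluoro at this carbon cannot be placed exactly against hydrogen or methoxy: the limit of > 50000 nM in this assay, at which 1 of the 4 values shown sits.

Hydrogen and methoxy are the only groups at this carbon with numbers, and whether any other group moves the value beyond the scatter remains open; an amine, a hydroxyl or a longer alkoxy chain here would test this. From the compounds shown here alone, compound 2 differs from the others in more than one place, so what each of its changes contributes alone also remains open.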